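This account rests on a few compounds, and the source may have more. Where it says the series, first, only, none or still open, it means among the compounds named here.

Measured compounds:
compound 1 `O=C(c1ccc2c(c1)OCCO2)N1N=C(c2ccc(Br)cc2)CC1c1ccccc1`: 1790 nM
compound 2 `O=C(c1ccc2c(c1)OCCO2)N1N=C(c2ccccc2)CC1c1ccc(F)cc1`: 5210 nM

In a functional assay on WM 266-4 cells (Homo sapiens) for inhibition, read by MTT assay, with a stated time of 24 h (a lower number here means a stronger inhibitor of growth, a higher number a weaker inhibitor of growth), compound 1 gives 1790 nM, and compound 2 gives 5210 nM, the highest of the two numbers shown; the two differ in more than one place, so only the two values themselves can be compared. Compound 3 `O=C(c1ccc2c(c1)OCCO2)N1N=C(c2ccc(Br)cc2)CC1c1ccc(F)cc1` has not been measured. It differs from compound 2 by bromo in place of hydrogen on an aromatic carbon. With compound 1, which also carries the bromo group, giving 1790 nM, the number for compound 3 is expected to move down, and the step from compound 2 is estimated as a 2.4-fold lower number from compound 2 to compound 3 (0.37 log units; beyond the scatter). In this assay compound 3 is expected at about 2200 nM, within 800 nM to 6000 nM.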

Compound 3, concentration for 50% growth inhibition: 3260 nM
The estimate for compound 3 lay 1.5-fold (0.17 log units) below the measured number; low and high end bracket the measured number.
By their numbers in this assay, from the lowest: compounds 1, 3 and 2 (each within the scatter of the next, the first and the last beyond it).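

Bromo in place of hydrogen, now read as a single change, gives a 1.6-fold lower number from compound 2 to compound 3 (0.20 log units; within the scatter) and so does not separate these two compounds in this assay. Fluoro in place of hydrogen, also read alone, gives a 1.8-fold higher number from compound 1 to compound 3 (0.26 log units; within the scatter) and likewise separates nothing. Compound 3 thus links compound 1 and compound 2 through single changes, each within the scatter, although compound 1 and compound 2 themselves lie beyond it. Going by these compounds, whether an amine or a carboxylic acid at the bromo position would give a step beyond the scatter stays open. Nothing available bears on the cause of these steps.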